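A few compounds are considered here, and "the series" means these few. Any claim that something is new, unique, unknown or untested is made for them only; others in the source may bear on it.

Series notes. Compound 1 `COc1cc(Cc2cnc(/N=C3\C(=O)N(CN4CCN(Cc5ccccc5)CC4)c4ccc(Cl)cc43)nc2N)cc(OC)c1OC` gives 94.7 ug/mL in an ADME assay on CCRF-CEM cells (Homo sapiens) for cytotoxicity, read by MTT assay, with a stated time of 5 days; on this read-out lower numbers stand for higher toxicity in this test and higher numbers for lower toxicity in this test. Compound 2 `COc1cc(Cc2cnc(/N=C3\C(=O)N(CN4CCN(c5ccc(Cl)cc5)CC4)c4ccc(Cl)cc43)nc2N)cc(OC)c1OC` gives 40.1 ug/mL in this assay, and compound 3 `COc1cc(Cc2cnc(/N=C3\C(=O)N(CN4CCN(c5cccc(Cl)c5)CC4)c4ccc(Cl)cc43)nc2N)cc(OC)c1OC` gives 34.4 ug/mL in this assay. Compound 3 holds the lowest number of the three: a 2.8-fold lower number from compound 1 to compound 3 (0.44 log units; beyond the scatter) lies beyond the scatter, whereas a 1.2-fold lower number from compound 2 to compound 3 (0.07 log units; within the scatter) lies within it. Compound 4 `COc1cc(Cc2cnc(/N=C3\C(=O)N(CN4CCN(c5ccc(F)cc5)CC4)c4ccc(Cl)cc43)nc2N)cc(OC)c1OC` differs from compound 3 as 4-fluorophenyl in place of 3-chlorophenyl on an amine nitrogen in a ring. Within the data shown here, the only measured step that alters the chlorophenyl group on the ring nitrogen, a 1.2-fold lower number from compound 2 to compound 3 (0.07 log units; within the scatter), stayed within the scatter; no measured step exchanges chlorine for fluorine. Compound 4 is therefore expected to show roughly a 1.2-fold higher number from compound 3 to compound 4 (0.07 log units; within the scatter) in this assay, with no change beyond the scatter. The estimate for compound 4 is 40 ug/mL, with a range from 20 ug/mL to 80 ug/mL.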

Compound 4, half-maximal cytotoxic concentration: 71 ug/mL
Estimate against measurement, compound 4: 1.8-fold (0.25 log units) below; the range from low to high includes it.
By their numbers in this assay, from the lowest: compounds 3, 2, 4 and 1 (each within the scatter of the next, the first and the last beyond it).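

Among the aryl groups on this ring nitrogen, a 2.1-fold higher number from compound 3 to compound 4 (0.31 log units; beyond the scatter) is the first step between them to pass the scatter in this assay, yet it changes both the halogen and the name-given ring position. With the 4-position kept, a 1.8-fold higher number from compound 2 to compound 4 (0.25 log units; within the scatter) stays within the scatter, and a 1.3-fold lower number from compound 1 to compound 4 (0.13 log units; within the scatter) shows that compound 4 goes against the separation from benzyl seen with both chlorophenyl compounds. No available evidence bears on the reason for these differences. As far as these compounds go, whether the halogen or its ring position drives the step remains open, and 3-fluorophenyl would separate the two. From the compounds shown here alone, how a 4-methoxyphenyl or an unsubstituted phenyl would read here is also open.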